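The source may report more compounds than this note shows. Statements on the series, on what has been measured and on what is new or still open speak of the compounds shown alone.

Compound 1 `COc1cc2c(Nc3nc4ccc(C(=O)Nc5c(C)cccc5C)cc4s3)ncnc2cc1OCCCN1CCCCC1` and compound 2 `COc1cc2c(Nc3nc4ccc(C(=O)Nc5c(C)cc(C)cc5C)cc4s3)ncnc2cc1OCCCN1CCCCC1` share one core and differ only in a methyl in place of hydrogen on an aromatic carbon. In a functional assay on HCT-116 cells (Homo sapiens) for cytotoxicity, read by WST assay, with a stated time of 72 h (a lower number here means a stronger inhibitor, a higher number a weaker inhibitor), compound 1 reaches only > 100000 nM, which is a limit of the measurement rather than a number. Compound 2 gives 16900 nM in this assay, the single actual number shown, and the step of an at least 5.9-fold lower number from compound 1 to compound 2 (0.77 log units; beyond the scatter) rests on that limit of > 100000 nM in this assay, at which 1 of the 2 values shown sits, at one end. Compound 3 `COc1cc2c(Nc3nc4ccc(C(=O)Nc5c(C)cc(C)cc5C)cc4s3)ncnc2cc1OCCCN1CCCC1` keeps the methyl pattern of compound 2 and instead alters the saturated ring on the chain: pyrrolidin-1-yl in place of piperidin-1-yl on a saturated chain carbon, three bonds along the chain from an oxygen on an aromatic ring. Among the compounds with values here, no measured step touches this part of the molecule, so the methyl step offers no guide here, and no change beyond the usual scatter is expected. For compound 3 the estimated value in this assay is 16900 nM, with a range from 7000 nM to 40000 nM. This corresponds to an expected step of no change at the digits printed from compound 2 to compound 3 (within the scatter).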

Compound 3, half-maximal inhibitory concentration: 5800 nM
Beside the measured number, compound 3's estimate is 2.9-fold (0.46 log units) above it, and the stated range ends above it.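

In this assay, pyrrolidin-1-yl in place of piperidin-1-yl gives a 2.9-fold lower number from compound 2 to compound 3 (0.46 log units; beyond the scatter), so the saturated ring at the end of the chain does affect the read-out. Within the data shown here, this is also the first step measured between two actual numbers, as the earlier methyl step rested on a limit. Nothing measured here explains why the five-membered ring gives the lower number.

On these data alone, whether other groups at this end of the chain, such as morpholin-4-yl or dimethylamino, would lower the number further remains open, as does the effect of a longer chain between the oxygen and the ring. It is also unknown whether pyrrolidin-1-yl would give a similar step on the core of compound 1, which lacks the added methyl.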